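Bromo for methyl on the benzyl ring of compound 3

The compounds below may be only part of what the source reports. "The series", "measured", "known", "first", "only" and "open" are said of these compounds alone.

Measured so far:
Compound 1, `O=[N+]([O-])c1ccccc1CSc1nnc(-c2ccc3c(c2)OCCO3)n1-c1ccccc1`, gives 69800 nM.
Compound 2, `Clc1ccccc1CSc1nnc(-c2ccc3c(c2)OCCO3)n1-c1ccccc1`, gives 29000 nM.
Compound 3, `Cc1ccc(CSc2nnc(-c3ccc4c(c3)OCCO4)n2-c2ccccc2)cc1`, gives 49700 nM.

Compound 3 was tested in a functional assay on HeLa cells (Homo sapiens) for antiproliferative activity, read by MTT assay, with a stated time of 24 h; on this read-out lower numbers stand for stronger inhibition and higher numbers for weaker inhibition. Among the three numbers it stands second highest: its nearest neighbour is compound 1, a step within the scatter, and its furthest is compound 2, also within the scatter, so compound 3 is not separated from either of them.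

Compound 4, `Brc1ccc(CSc2nnc(-c3ccc4c(c3)OCCO4)n2-c2ccccc2)cc1`, has not yet been measured in this assay. It differs from compound 3 in one place: bromo in place of methyl on an aromatic carbon. The change sits on an aromatic carbon of a six-membered aromatic ring of carbon only, para to a large group.

Among the compounds with values here, no measured step changes the same position, so the bearing is indirect. The step of a 2.4-fold lower number from compound 1 to compound 2 (0.38 log units; beyond the scatter) shows a halogen in place of another group on the benzyl ring giving a modest lower number, while a 1.7-fold higher number from compound 2 to compound 3 (0.23 log units; within the scatter) shows the chlorophenyl and methylphenyl variants within the scatter of each other. The account therefore expects at most a small step for compound 4, if anything toward a lower number, and estimates a 1.3-fold lower number from compound 3 to compound 4 (0.12 log units; within the scatter). Compound 4 is thus expected to give about 38000 nM, within a range from 15000 nM to 90000 nM.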

Compound 4, half-maximal inhibitory concentration: 54600 nM
Compound 4: the middle estimate sits 1.4-fold (0.16 log units) below what was measured; the measured number falls inside the stated range.
By their numbers in this assay, from the lowest: compounds 2, 3, 4 and 1 (each within the scatter of the next, the first and the last beyond it).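

In this assay, within the data shown here, the step from 4-methylbenzyl to 4-bromobenzyl is the first reading at this place on the ring, and at a 1.1-fold higher number from compound 3 to compound 4 (0.04 log units; within the scatter) it leaves methyl and bromo indistinguishable here. Among these compounds, compound 4 also cannot be separated from either compound carrying a substituted benzyl group of another kind, with a 1.9-fold higher number from compound 2 to compound 4 (0.27 log units; within the scatter) and a 1.3-fold lower number from compound 1 to compound 4 (0.11 log units; within the scatter), even though those two compounds stand apart from each other at a 2.4-fold lower number from compound 1 to compound 2 (0.38 log units; beyond the scatter), so the only pair separated among the four remains compound 1 and compound 2. No measurement is available that could explain why these numbers fall as they do.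

The compounds shown carry only methyl and bromo at this place on the aromatic ring, so it stays open what an amine or a carboxylic acid there would give in this assay. From the compounds shown here alone, it is also open whether a longer chain in place of the single saturated carbon bound to the sulfur, or a change to the shared core, would move the number beyond the scatter.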